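The source may report more compounds than this note shows. Statements on the series, on what has been measured and on what is new or still open speak of the compounds shown alone.

Compound 1 `COc1ccc(/C=C/C(=O)c2c(O)cc(O)cc2OC)cc1OC`: 49500 nM
Compound 2 `COc1cc(O)cc(O)c1C(=O)/C=C/c1ccc([N+](=O)[O-])cc1`: > 50000 nM
Compound 3 `COc1cc(OC)c(C(=O)/C=C/c2ccc(O)cc2)c(OC)c1`: 40600 nM

All three compounds were tested in a functional assay on HeLa cells (Homo sapiens) for inhibition, read by MTT assay, with a stated time of 72 h; a lower number here means a stronger inhibitor, a higher number a weaker inhibitor. For compound 2, the entry > 50000 nM is a limit of the assay and not a number.

Only two of the three results are therefore true numbers. Compound 3 gives 40600 nM and compound 1 gives 49500 nM. These two values lie within the scatter of each other, so they cannot be ranked, and both mark weak inhibition.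

The next compound to be measured is compound 4 `COc1cc(OC)c(C(=O)/C=C/c2ccc(O)c(O)c2)c(OC)c1`, which differs from compound 3 in one place: hydroxy in place of hydrogen on an aromatic carbon. A hydroxy group takes the place of a hydrogen on an aromatic carbon, ortho to a hydroxy group and meta to a large group, so that 4-hydroxyphenyl becomes 3,4-dihydroxyphenyl.

Going by the values given here, no measured pair of compounds differs in just one place, so this assay offers no direct guide to the size of this change. The expectation is therefore cautious: a small shift toward a lower number, staying within the scatter. The expected step is a 1.4-fold lower number from compound 3 to compound 4 (0.13 log units; within the scatter). For compound 4, the estimated value is 30000 nM, with an expected range of 12000 nM to 50000 nM.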

Compound 4, half-maximal inhibitory concentration: 15800 nM
Beside the measured number, compound 4's estimate is 1.9-fold (0.28 log units) above it, within the range that was stated.
By their numbers in this assay, from the lowest: compound 4; then compounds 3 and 1 (each within the scatter of the next). At a limit, above all of these: compound 2.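

In this assay, adding a hydroxy group on an aromatic carbon, ortho to a hydroxy group and meta to a large group, turns 4-hydroxyphenyl into 3,4-dihydroxyphenyl and gives a 2.6-fold lower number from compound 3 to compound 4 (0.41 log units; beyond the scatter). Going by these compounds alone, this is the first change in one place that can be read, and it shows that the number responds to substitution at this position, although the step is modest. The compounds shown give no measured property that accounts for this step.

On these data alone, it remains open whether the lower number needs a hydroxy group at this position specifically, or whether a methoxy group, an amine or a fluorine in the same place would give a similar step. As far as these compounds go, it is also open whether the new hydroxy group acts only together with the existing one, which a 3-hydroxyphenyl compound would test, and whether the same change would give a step of similar size on the core of compound 1.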